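This account rests on a few compounds, and the source may have more. Where it says the series, first, only, none or still open, it means among the compounds named here.

Compound 1 `CCOC(=O)C1=Cc2ccccc2OC1(OCc1cn(CC(=O)Nc2ccccc2Br)nn1)C(F)(F)F` is one of three members of this series measured in a functional assay on MCF7 cells (Homo sapiens) for inhibition, read by MTT assay, with a stated time of 24 h; on this read-out lower numbers stand for stronger inhibition and higher numbers for weaker inhibition. In this assay compound 1 gives > 150000 nM, which is a limit of the assay rather than a number. Compound 2 `O=C(O)C1=Cc2ccccc2OC1(OCc1cc(-c2ccc(F)cc2F)no1)C(F)(F)F` likewise gives > 150000 nM, also a limit. Compound 3 `CCOC(=O)C1=Cc2ccccc2OC1(OCc1cc(-c2ccc([N+](=O)[O-])cc2)no1)C(F)(F)F` gives > 150000 nM, again a limit. For the measured compounds named here, the series so far shows only (the limit of > 150000 nM in this assay, at which 3 of the 3 values shown sit), so compound 1 cannot be placed against the others. Compound 4 `CCOC(=O)C1=Cc2ccccc2OC1(OCc1cn(CC(=O)Nc2ccc(I)cc2Cl)nn1)C(F)(F)F` carries 2-chloro-4-iodophenyl in place of 2-bromophenyl on an amide-type nitrogen. Going by the values given here, no measured pair shows what such a change does here. The step expected is a step that the limit leaves unreadable from compound 1 to compound 4, none beyond the scatter, with another limit the likeliest outcome. Compound 4 is therefore estimated at 200000 nM, in the range 100000 nM to 400000 nM.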

Compound 4, half-maximal inhibitory concentration: 28100 nM
The estimate for compound 4 lay 7.1-fold (0.85 log units) above the measured number; measured number below the stated range.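

In this assay, the aryl group on the amide-type nitrogen can move the read-out: 2-chloro-4-iodophenyl in place of 2-bromophenyl gives an at least 5.3-fold lower number from compound 1 to compound 4 (0.72 log units; beyond the scatter). Compound 4 is the only member shown with a number rather than a limit, so this position is the one place in the series where a change can be read: the limit of > 150000 nM in this assay, at which 3 of the 4 values shown sit.

The step swaps both halogens at once, so the chlorine and the iodine cannot be told apart. As far as these compounds go, whether an amine or a methoxy group in place of the iodine would keep the lower number stays open.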